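Benzyloxy in place of methoxy on a chromone series

The source may report more compounds than this note shows. Statements on the series, on what has been measured and on what is new or still open speak of the compounds shown alone.

Measured compounds:
compound 1, `Cc1cc(=O)oc2cc(Sc3cccc(Cl)[n+]3[O-])ccc12`, 24500 nM
compound 2, `CCc1cc(=O)c2ccc(OCc3cccc(C#N)c3)c(C)c2o1`, > 31300 nM
compound 3, `CCc1oc2c(C)c(OC)ccc2c(=O)c1Br`, 23200 nM

In a functional assay on KBVIN cells (Homo sapiens) for antiproliferative activity, read by sulforhodamine B assay, with a stated time of 72 h (on this read-out lower numbers stand for stronger inhibition of growth and higher numbers for weaker inhibition of growth), compound 3 gives 23200 nM, the lowest of the two numbers that were obtained. The nearest number belongs to compound 1 with 24500 nM, which lies within the scatter of compound 3, so the two cannot be put in order. For compound 2 this assay reports only a limit, > 31300 nM, and not a number; compound 2 shares with the unmeasured compound an ether carrying an aromatic ring, but it differs from compound 3 in more than one place, so its value shows only that it reached the limit.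

Compound 4, `CCc1oc2c(C)c(OCc3ccccc3)ccc2c(=O)c1Br`, has not yet been measured. It differs from compound 3 by phenyl in place of hydrogen on a saturated chain carbon bound to an oxygen on an aromatic ring. Among the compounds with values here, no step between measured compounds bears on this change, so the expectation rests on compound 3 alone. The step from compound 3 is expected to be a 1.1-fold higher number from compound 3 to compound 4 (0.03 log units; within the scatter), that is no change beyond the scatter in either direction. Compound 4 is therefore estimated at 25000 nM, with a range from 8000 nM to 70000 nM, and a fair chance that this assay again reports only a limit.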

Compound 4, concentration for 50% growth inhibition: > 26700 nM
Compound 4: no number, only a limit; the forecaster's own chance of this, stated with the estimate: 35%; at least 1.0-fold (0.02 log units) between middle value and limit.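

In this assay compound 4 gives no number, only a limit: the limit of > 26700 nM in this assay, at which 1 of the 4 values shown sits.

Methyl to benzyl on the oxygen of the aromatic ring gives an at least 1.1-fold higher number from compound 3 to compound 4 (0.06 log units; that floor lies within the scatter). From the compounds shown here alone, compound 3 alone could not show what a large aromatic group does at this place; the pair now shows that phenyl on this saturated chain carbon brings no stronger inhibition of growth, while the floor of the step does not establish a weakening beyond the scatter, and how far compound 4 lies from compound 3 stays unknown.

The compounds shown do not tell whether the result belongs to the phenyl ring itself or to the greater size of the ether, and a 2-phenylethyl ether, a benzyl carrying a nitrile on the same core, or a 2-aminoethyl ether on this oxygen would bear on that question. Going by these compounds, the bromine on the core is common to compound 3 and compound 4, so what hydrogen or a carboxylic acid in its place would do to the methyl and benzyl ethers also stays open.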